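The compounds below may be only part of what the source reports. "The series", "measured", "known", "first", "only" and "open" are said of these compounds alone.

Working notes on the series.

In a functional assay on NCI-H226 cells (Homo sapiens) for inhibition, read by sulforhodamine B assay, with a stated time of 48 h (on this read-out higher numbers stand for weaker inhibition of growth and lower numbers for stronger inhibition of growth), compound 1 `COc1cc(C)cc(-c2c(-c3ccnc(-c4ccc(C(C)=O)cc4)c3)cnn2CC#N)c1` gives only a limit, > 100000 nM. Compound 2 `COc1cc(C)cc(-c2nn(CC#N)cc2-c2ccc(-c3cccc(C(C)=O)c3)nc2)c1` gives 82300 nM in this assay. Compound 3 `Cc1cc(O)cc(-c2nn(CC#N)cc2-c2ccnc(-c3ccc(Oc4ccccc4)cc3)c2)c1` gives 12200 nM in this assay, the lower of the two numbers on record; the number for compound 2 stands higher, beyond the usual scatter. Compound 4 `Cc1cc(O)cc(-c2nn(CC#N)cc2-c2ccnc(-c3ccc(N(C)C)cc3)c2)c1` has not yet been measured in this assay. It differs from compound 3 by dimethylamino in place of phenoxy on an aromatic carbon. Going by the values given here, no measured pair in the set carries this change, so its size is not known from the data; the expectation is for a step no larger than the scatter, leaning toward a somewhat higher number. Compound 4 is expected to give about 20000 nM in this assay, within a range from 5000 nM to 80000 nM. That amounts to an expected step of a 1.6-fold higher number from compound 3 to compound 4 (0.21 log units; within the scatter).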

Compound 4, concentration for total growth inhibition: 21800 nM
Beside the measured number, compound 4's estimate is 1.1-fold (0.04 log units) below it, and the stated range covers the measured number.
By their numbers in this assay, from the lowest: compounds 3 and 4 (each within the scatter of the next); then compound 2. At a limit, above all of these: compound 1.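

Dimethylamino in place of phenoxy on an aromatic carbon, para to a large group, gives a 1.8-fold higher number from compound 3 to compound 4 (0.25 log units; within the scatter) in this assay. The six-membered aromatic ring of carbon only can therefore leave this position with no step beyond the scatter, so the ring itself is not needed to hold the number here. Only compound 1 sits at a limit, so this step reads as a number: the limit of > 100000 nM in this assay, at which 1 of the 4 values shown sits.

From the compounds shown here alone, what a carboxylic acid or a morpholine on this carbon would give stays open. Going by these compounds, whether any group here can move the number beyond the scatter also stays open.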